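The compounds below may be only part of what the source reports. "The series", "measured", "known", "first", "only" and "open" are said of these compounds alone.

Measured in an ADME assay on WI-38 cells (Homo sapiens) for cytotoxicity, read by sulforhodamine B assay, with a stated time of 24 h; a higher number here means a weaker inhibitor, a lower number a stronger inhibitor:
compound 1 `O=C1Nc2ccc(S(=O)(=O)N3CCOCC3)cc2/C1=N/c1ccc(Br)cc1`: 372000 nM
compound 2 `O=C1Nc2ccc(S(=O)(=O)N3CCOCC3)cc2/C1=N/c1ccc(C(=O)O)cc1`: 313000 nM

Compound 2 at 313000 nM stands within the scatter of compound 1, so no order can be read between the two. The next compound is compound 3 `CC(=O)c1cccc(/N=C2\C(=O)Nc3ccc(S(=O)(=O)N4CCOCC4)cc32)c1`. The change is 3-acetylphenyl in place of 4-carboxyphenyl on a double-bonded nitrogen, in words 3-acetylphenyl in place of 4-carboxyphenyl on a double-bonded nitrogen. Going by the values given here, the only measured step that bears on it is a 1.2-fold lower number from compound 1 to compound 2 (0.07 log units; within the scatter), with carboxy in place of bromo on an aromatic carbon. Among the compounds with values here, that step stays within the scatter, but it is a single step, and no measured compound carries 3-acetylphenyl. The expectation in this assay is therefore no change beyond the scatter, in either direction. The expected size is a 1.1-fold higher number from compound 2 to compound 3 (0.02 log units; within the scatter). For compound 3 the estimated value is 330000 nM, with an expected range of 150000 nM to 700000 nM.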

Compound 3, half-maximal inhibitory concentration: 177000 nM
Estimate against measurement, compound 3: 1.9-fold (0.27 log units) above; measured number inside the range.
By their numbers in this assay, from the lowest: compounds 3, 2 and 1 (each within the scatter of the next, the first and the last beyond it).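

In this assay, going by these compounds alone, the group on the double-bonded nitrogen now gives a first step beyond the scatter, though a modest one: 3-acetylphenyl in place of 4-bromophenyl gives a 2.1-fold lower number from compound 1 to compound 3 (0.32 log units; beyond the scatter) in this series. Against 4-carboxyphenyl the same group gives a 1.8-fold lower number from compound 2 to compound 3 (0.25 log units; within the scatter) and stays within the scatter, so compound 3 separates from compound 1 only, and compound 2 cannot be ordered against either. Nothing measured here offers an explanation for these steps.

The compounds shown leave open whether the step follows the acetyl group or its place on the phenyl ring, which 4-acetylphenyl or 3-bromophenyl would separate. Also open, going by these compounds, is whether an amine or a longer chain on that ring would move the number outside the span of these three compounds.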